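The source may report more compounds than this note shows. Statements on the series, on what has been measured and on what is new or still open speak of the compounds shown alone.

In a functional assay on L1210 cells (Mus musculus) for inhibition, read by MTT assay, with a stated time of 72 h (a higher number here means a weaker inhibitor, a lower number a stronger inhibitor), three compounds sharing one core have been measured. Compound 1 `COc1cc(NC(C)CCCNC(=O)Nc2cccc(Cl)c2)c2ncccc2c1` gives 17000 nM and compound 3 `COc1cc(NC(C)CCCNC(=O)Nc2ccc(F)cc2)c2ncccc2c1` gives 18000 nM. These two values are effectively level, as the step of a 1.1-fold higher number from compound 1 to compound 3 (0.02 log units; within the scatter) shows. Compound 2 `COc1cc(NC(C)CCCNC(=O)NNC(=O)Nc2ccc(Cl)cc2)c2ncccc2c1` gives 58000 nM, making it the weakest of the three.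

Compound 4 `COc1cc(NC(C)CCCNC(=O)NNC(=O)Nc2cccc(F)c2)c2ncccc2c1` has ((3-fluorophenyl)carbamoyl)amino in place of 4-fluorophenyl on an amide-type nitrogen.

Going by the values given here, the nearest precedent is compound 2, the only measured compound with a group of this longer kind, ((4-chlorophenyl)carbamoyl)amino. Among the compounds with values here, two steps bear on the change: a 3.4-fold higher number from compound 1 to compound 2 (0.53 log units; beyond the scatter), and a 3.2-fold lower number from compound 2 to compound 3 (0.51 log units; beyond the scatter), which is the same kind of swap run in the opposite direction. Both are modest. Within the data shown here, no measured compound carries ((3-fluorophenyl)carbamoyl)amino itself, so this comparison is only approximate.

A modest rise of similar size is therefore expected, with the expected step being a 3.1-fold higher number from compound 3 to compound 4 (0.49 log units; beyond the scatter). The estimate for compound 4 is 55000 nM, with an expected range of 25000 nM to 120000 nM.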

Compound 4, half-maximal inhibitory concentration: 108000 nM
Beside the measured number, compound 4's estimate is 2.0-fold (0.29 log units) below it, within the range that was stated.
By their numbers in this assay, from the lowest: compounds 1 and 3 (each within the scatter of the next); then compounds 2 and 4 (each within the scatter of the next).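

The drop seen with compound 2 is not a one-off. The same kind of longer group, here ((3-fluorophenyl)carbamoyl)amino, again raises the number, with a 6.0-fold higher number from compound 3 to compound 4 (0.78 log units; beyond the scatter) and a 6.4-fold higher number from compound 1 to compound 4 (0.80 log units; beyond the scatter) as the two steps from the shorter compounds. Within the longer pair, 3-fluorophenyl in place of 4-chlorophenyl gives a 1.9-fold higher number from compound 2 to compound 4 (0.27 log units; within the scatter) and so does not separate the two, which suggests that among these four compounds the longer group matters more than the halogen on its ring. Nothing shown explains why the longer group goes with weaker inhibition.

Every step from a shorter to a longer group among these compounds also changes the halogen or its ring position, so the effect of length alone remains unresolved. From the compounds shown here alone, it is also open how either group would behave with a methoxy group or a carboxylic acid on its ring in place of the halogen.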